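This account rests on a few compounds, and the source may have more. Where it says the series, first, only, none or still open, it means among the compounds named here.

Compound 1 `Cc1ccc(-n2ccnc2SCC(=O)Nc2ccccc2[N+](=O)[O-])cc1`: 131000 nM
Compound 2 `O=C(CSc1nccn1-c1ccc(Cl)cc1)Nc1ccccc1Br`: > 300000 nM (a limit)
Compound 3 `Cc1ccc(-n2ccnc2SCC(=O)Nc2ccccc2C)cc1`: 147000 nM

In an ADME assay on MT4 cells (Homo sapiens) for cytotoxicity, read by MTT assay (a lower number here means that less compound is tolerated, a higher number that more compound is tolerated), compound 1 gives 131000 nM and compound 3 gives 147000 nM, the two values lying within the scatter of each other. Compound 2 reaches only a limit of this assay, > 300000 nM. Among the compounds with values here, the one measured step that changes a single group is a 1.1-fold higher number from compound 1 to compound 3 (0.05 log units; within the scatter).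

Compound 4 `Cc1ccc(-n2ccnc2SCC(=O)Nc2ccccc2Br)cc1` is not yet measured in this assay. It differs from compound 3 by bromo in place of methyl on an aromatic carbon. Within the data shown here, no measured step covers this exchange; compound 2, which also carries a bromo group but differs in a second place as well, shows only (the limit of > 300000 nM in this assay, at which 1 of the 3 values shown sits). Given the step from compound 1 to compound 3, a change within the scatter is expected, with some chance of a limit. Compound 4 is estimated at 170000 nM (85000 nM to 340000 nM), an expected step of a 1.2-fold higher number from compound 3 to compound 4 (0.06 log units; within the scatter).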

Compound 4, half-maximal cytotoxic concentration: 39300 nM
Compound 4: middle estimate off by 4.3-fold (0.64 log units), on the high side, outside the stated range (below it).
By their numbers in this assay, from the lowest: compound 4; then compounds 1 and 3 (each within the scatter of the next). At a limit, above all of these: compound 2.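

In this assay, bromo on this aromatic carbon sets compound 4 apart from both earlier groups, with a 3.7-fold lower number from compound 3 to compound 4 (0.57 log units; beyond the scatter) and a 3.3-fold lower number from compound 1 to compound 4 (0.52 log units; beyond the scatter), although methyl and nitro here lie within the scatter of each other. A change elsewhere in the series also separates two compounds, methyl in place of chloro, with an at least 7.6-fold lower number from compound 2 to compound 4 (0.88 log units; beyond the scatter). Compound 2 gives no exact number, only a limit: the limit of > 300000 nM in this assay, at which 1 of the 4 values shown sits.

From the compounds shown here alone, whether fluoro, an amine or a carboxylic acid on this aromatic carbon would track with bromo or with methyl and nitro remains open. So does whether the lower number of compound 4 persists with other groups in place of its methyl.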